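This account rests on a few compounds, and the source may have more. Where it says the series, first, only, none or still open, it means among the compounds named here.

Of the compounds shown here, three have so far been tested in a functional assay on SGC-7901 cells (Homo sapiens) for antiproliferative activity, read by sulforhodamine B assay, with a stated time of 72 h; on this read-out lower numbers stand for stronger inhibition and higher numbers for weaker inhibition. Compound 1 `CN(C)C(=S)N/N=C/c1ccc2ccccc2n1` gives 30 nM in this assay. Compound 2 `NC(=S)N/N=C/c1ccc2ccccc2n1` differs from compound 1 in one place, (amino in place of dimethylamino on a thiocarbonyl carbon), and in this assay compound 2 gives 32700 nM. That single change thus made a very large step, a 1100-fold higher number from compound 1 to compound 2 (3.04 log units; beyond the scatter). Compound 3 `CN(C)C(=S)N/N=C/c1cnc2ccccc2n1` carries a different core; how the core of compound 3 differs from the core of compound 1 is not broken down here. In this assay compound 3 gives 170 nM, which stands between the numbers of compound 1 and compound 2.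

Compound 4 `NC(=S)N/N=C/c1cnc2ccccc2n1` has not yet been measured. It differs from compound 3 in the same way that compound 2 differs from compound 1: amino in place of dimethylamino on a thiocarbonyl carbon. The place is described in the same words for both pairs, so this is the same change on a different core. Because that change produced a 1100-fold higher number from compound 1 to compound 2 (3.04 log units; beyond the scatter) on the core of compound 1, a step of similar direction and size is expected here, namely a 590-fold higher number from compound 3 to compound 4 (2.77 log units; beyond the scatter). This expectation rests on one earlier instance only, and with numbers this high the assay may report only a limit rather than a number. Compound 4 is therefore expected to give about 100000 nM in this assay, most likely between 20000 nM and 400000 nM.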

Compound 4, half-maximal inhibitory concentration: > 100000 nM
Compound 4: a limit, no number; the forecaster's own chance of this, stated with the estimate: 30%; the middle value lies on the limit itself.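

In this assay compound 4 gives > 100000 nM, which is a limit of the assay and not a number. Even so, it marks an at least 580-fold higher number from compound 3 to compound 4 (2.76 log units; beyond the scatter), so amino in place of dimethylamino on a thiocarbonyl carbon moves the result the same way on both cores shown, to a much higher number and thus much weaker inhibition. This does not show that the step has the same size on the two cores, and two cores are too few to make a rule for the whole series: the same change on two cores in this assay, a 1100-fold higher number (3.04 log units; beyond the scatter) from compound 1 to compound 2 and an at least 580-fold higher number (2.76 log units; beyond the scatter) from compound 3 to compound 4; the limit leaves it open whether they differ

All four compounds shown carry either amino or dimethylamino at this place, so they leave open where methylamino, with its single methyl group on the nitrogen, or diethylamino, with two longer chains, would fall on this scale. They also leave open whether the same large step would appear on any core beyond these two, and a measured number for compound 4 rather than a limit would be needed to compare the two steps directly.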